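Swapping the piperidine substituent and rat plasma unbound fraction

This account rests on a few compounds, and the source may have more. Where it says the series, first, only, none or still open, it means among the compounds named here.

Compound 1 `COc1cc2nnc(C(N)=O)c(Nc3ccc(C)cc3F)c2cc1N1CCN(C)CC1` gives 0.063 in an ADME assay on a cell-free system (plasma, Rattus norvegicus) for protein binding; a higher number here means a larger unbound share of the compound, a lower number a smaller unbound share. Among the measured compounds shown here, compound 2 `COc1cc2nnc(C(N)=O)c(Nc3ccc(C)cc3F)c2cc1N1CCC(N(C)C)CC1` gives 0.15 in this assay, the higher of the two numbers measured so far, and the step of a 2.4-fold higher number from compound 1 to compound 2 (0.38 log units; beyond the scatter) separates it from compound 1. Compound 3 `COc1cc2nnc(C(N)=O)c(Nc3ccc(C)cc3F)c2cc1N1CCC(OC)CC1` differs from compound 2 in one place: methoxy in place of dimethylamino on a saturated ring carbon. For the measured compounds named here, no measured step covers this exchange; the only step on record, a 2.4-fold higher number from compound 1 to compound 2 (0.38 log units; beyond the scatter), alters the ring that carries the basic nitrogen rather than the group on the saturated ring carbon, so it bears only indirectly and gives no direction for the new change. Compound 3 is therefore expected to sit near compound 2, with a step of a 1.7-fold lower number from compound 2 to compound 3 (0.22 log units; within the scatter) that could fall inside the scatter. Compound 3 is estimated at 0.09, within a range of 0.03 to 0.25.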

Compound 3, unbound fraction: 0.012
For compound 3 the middle estimate is 7.5-fold (0.88 log units) above the measured one; the measured number lies below the stated range.
By their numbers in this assay, from the lowest: compound 3; then compound 1; then compound 2.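

In this assay the group on the saturated ring carbon carries far more weight than the two earlier compounds could show: methoxy in place of dimethylamino gives a 13-fold lower number from compound 2 to compound 3 (1.10 log units; beyond the scatter) and puts 4-methoxypiperidin-1-yl at the bottom of the series. The exchange of 4-methylpiperazin-1-yl for 4-methoxypiperidin-1-yl gives a 5.3-fold lower number from compound 1 to compound 3 (0.72 log units; beyond the scatter) in the same direction, so among these three compounds the two that carry a further amine both stand above compound 3. No measured evidence on record accounts for this fall.

The compounds shown leave open whether the fall follows the loss of the amine or the arrival of the methoxy group. A hydroxyl, a primary amine or a carboxylic acid on the same ring carbon would help to separate the two.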